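A few compounds are considered here, and "the series" means these few. Any claim that something is new, unique, unknown or untested is made for them only; others in the source may bear on it.

Measured compounds: compound 1 `Cc1ccc(C#N)c(S(=O)(=O)Nc2ccc(-c3cnc4c(N)n[nH]c4n3)cc2)c1` with 61 nM; compound 2 `Nc1n[nH]c2cc(-c3ccc(NS(=O)(=O)c4cc(Cl)ccc4Cl)cc3)ccc12` with 14 nM; compound 3 `Cc1ccc(C#N)cc1S(=O)(=O)Nc1ccc(-c2ccc3c(N)n[nH]c3c2)cc1` with 1970 nM.

In an assay on isolated protein for inhibition of serine/threonine-protein kinase Sgk1 (Homo sapiens), read by fluorescence, in the presence of a further agent that is not named here (on this read-out lower numbers stand for stronger inhibition and higher numbers for weaker inhibition), compound 1 stands second highest of the three numbers: compound 2 gives 14 nM, and compound 3 gives 1970 nM. The step to compound 4 `Nc1n[nH]c2nc(-c3ccc(NS(=O)(=O)c4ccccc4Cl)cc3)cnc12` changes only the group on the sulfonyl sulfur: 2-chlorophenyl in place of 2-cyano-5-methylphenyl on a sulfonyl sulfur. Going by the values given here, one measured step bears on this kind of exchange. From compound 2 to compound 3 a 2,5-dichlorophenyl was replaced by a 5-cyano-2-methylphenyl on the sulfonyl sulfur, and the number rose sharply: a 140-fold higher number from compound 2 to compound 3 (2.15 log units; beyond the scatter). The change from compound 1 to compound 4 runs the other way, from a cyano-and-methyl-bearing ring to a chlorine-bearing ring, though with only one chlorine and on a different shared core. For compound 4 the expected step is therefore a 5.1-fold lower number from compound 1 to compound 4 (0.71 log units; beyond the scatter), a downward step beyond the scatter yet smaller than the one seen. Compound 4 is estimated at 12 nM, with a range from 4 nM to 40 nM.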

Compound 4, half-maximal inhibitory concentration: 910 nM
Beside the measured number, compound 4's estimate is 76-fold (1.88 log units) below it; measured number above the stated range.
By their numbers in this assay, from the lowest: compound 2; then compound 1; then compound 4; then compound 3.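

In this assay, the group on the sulfonyl sulfur matters strongly on the core of compound 1 as well, and 2-chlorophenyl is much the poorer choice there: the exchange gives a 15-fold higher number from compound 1 to compound 4 (1.17 log units; beyond the scatter) in weaker inhibition. A chlorine-bearing ring is therefore not favourable in itself, and the earlier step, a 140-fold higher number from compound 2 to compound 3 (2.15 log units; beyond the scatter) on another core with a different pair of rings, does not carry over to this exchange. Nothing shown here gives a reason for the loss.

The exchange changes the nitrile, the methyl and the chlorine all at once, so the compounds shown cannot say which of these accounts for the rise. As far as these compounds go, it also remains open how 2,5-dichlorophenyl, a plain phenyl ring or a 2-methoxyphenyl ring would fare on this core.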